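Nitro on the phenyl of compound 1

A few compounds are considered here, and "the series" means these few. Any claim that something is new, unique, unknown or untested is made for them only; others in the source may bear on it.

This account follows a single change on the phenyl ring of compound 1 `Nc1nc(N)c2cc(CSC(=S)N3CCN(c4ccccc4)CC3)ccc2n1`. In a functional assay on HT-29 cells (Homo sapiens) for antiproliferative activity, read by MTT assay, with a stated time of 72 h (on this read-out lower numbers stand for stronger inhibition and higher numbers for weaker inhibition), compound 1 gives 2760 nM. Within the data shown here, on the numbers so far compound 1 holds the lowest of two values; its only neighbour, compound 2 `Cc1ccc(N2CCN(C(=S)SCc3ccc4nc(N)nc(N)c4c3)CC2)cc1`, gives 3020 nM in this assay, and the step of a 1.1-fold higher number from compound 1 to compound 2 (0.04 log units; within the scatter) lies within the scatter, so the two cannot be ranked.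

Compound 3 `Nc1nc(N)c2cc(CSC(=S)N3CCN(c4ccccc4[N+](=O)[O-])CC3)ccc2n1` has not been measured. It differs from compound 1 by nitro in place of hydrogen on an aromatic carbon. Among the measured compounds shown here, the only measured step that bears on it is the one to compound 2, which also puts a new group on an aromatic carbon of this phenyl ring; that step was flat. The nitro group is larger and carries two hydrogen-bond acceptors, so the comparison is imperfect, yet nothing measured points to a clear move in either direction.

Compound 3 is therefore expected to stay close to compound 1, with the step of a 1.0-fold higher number from compound 1 to compound 3 (0.01 log units; within the scatter) and an estimated value of 2800 nM, ranging from 1200 nM to 6500 nM.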

Compound 3, half-maximal inhibitory concentration: 4310 nM
The estimate for compound 3 lay 1.5-fold (0.19 log units) below the measured number; low and high end bracket the measured number.
By their numbers in this assay, from the lowest: compounds 1, 2 and 3 (each within the scatter of the next).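

In this assay, the step of a 1.6-fold higher number from compound 1 to compound 3 (0.19 log units; within the scatter) shows that nitro in place of hydrogen on this aromatic carbon, ortho to a large group, gives a number that cannot be told apart from that of the unsubstituted phenyl. The step of a 1.4-fold higher number from compound 2 to compound 3 (0.15 log units; within the scatter) shows the same for 2-nitrophenyl against 4-methylphenyl, so the phenyl ring now carries two quite different groups, in different places, and none of the three compounds can be ranked against another. Unlike the methyl of compound 2, the nitro group brings in heavy atoms other than carbon, yet no measured information here bears on what lies behind these numbers.

What the compounds shown leave open is whether an amine or a carboxylic acid on this phenyl ring would move the number beyond the scatter, or whether this ring accepts such groups just as flatly. They also leave open whether the nitro group would read the same on another carbon of the ring, where it would no longer stand ortho to the large group.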